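A few compounds are considered here, and "the series" means these few. Any claim that something is new, unique, unknown or untested is made for them only; others in the source may bear on it.

Measured in a physicochemical assay for solubility; a lower number here means a less soluble compound, a higher number a more soluble compound:
- compound 1 `C[C@@H](Nc1ncc(C(=O)Nc2nc(-c3cccc(C(F)(F)F)c3F)cs2)cc1Cl)C(=O)O`: < 10 ug/mL
- compound 2 `O=C(Nc1nc(-c2cccc(C(F)(F)F)c2F)cs1)c1ccc(N2CCC(C(=O)O)CC2)nc1`: < 10 ug/mL

Compound 1 stands at a limit of this assay, < 10 ug/mL, and not at a number. Compound 2 also gives only a limit. Within the data shown here, the picture so far is the limit of < 10 ug/mL in this assay, at which 2 of the 2 values shown sit, so no measured step is available.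

Compound 3 `O=C(Nc1nc(-c2cccc(C(F)(F)F)c2F)cs1)c1cnc(N2CCCCC2)c(Cl)c1`, not yet measured, carries piperidin-1-yl in place of (1-carboxyethyl)amino on an aromatic carbon, ortho to a chloro group: piperidin-1-yl in place of (1-carboxyethyl)amino on an aromatic carbon. No step beyond the scatter is expected in this assay, and a reading at the same limit is the likeliest outcome. This expectation rests on the limit of compound 1, < 10 ug/mL. The expected step is a step that the limit leaves unreadable from compound 1 to compound 3. The estimate for compound 3 is 5 ug/mL, with an expected range from 1 ug/mL to 15 ug/mL.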

Compound 3, solubility: < 10 ug/mL
Compound 3: no number, only a limit; the forecaster's own chance of this, stated with the estimate: 85%; the middle value lies beyond the limit too.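

Among these compounds, compound 3 gives only a limit in this assay, < 10 ug/mL, and compound 1 also stands at a limit, so no step between them can be read. The compounds shown leave open where any of them truly lies, and whether any change to the shared core gives a readable number: the limit of < 10 ug/mL in this assay, at which 3 of the 3 values shown sit.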